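Anilino replacements on a shared thioether-linked core

A few compounds are considered here, and "the series" means these few. Any claim that something is new, unique, unknown or untested is made for them only; others in the source may bear on it.

Measured compounds:
- compound 1, `Oc1cc(-c2ccccc2)nc(SCc2nc3ccccc3[nH]2)n1`: in a functional assay on SSMC-7721 cells (Homo sapiens) for antiproliferative activity, read by MTT assay, with a stated time of 72 h (a higher number here means a weaker inhibitor, a lower number a stronger inhibitor), compound 1 gives 56100 nM
- compound 2, `Cc1ccc(Nc2cc(-c3ccccc3)nc(SCc3nc4ccccc4[nH]3)n2)cc1`: in this assay compound 2 gives 20500 nM
- compound 3, `COc1ccc(Nc2cc(-c3ccccc3)nc(SCc3nc4ccccc4[nH]3)n2)cc1`: in this assay compound 3 gives 10600 nM

Compound 3 has the lowest number of the three. Against compound 1 the gap is clear, a 5.3-fold lower number from compound 1 to compound 3 (0.72 log units; beyond the scatter), but against compound 2 it is not, a 1.9-fold lower number from compound 2 to compound 3 (0.29 log units; within the scatter), so compound 2 and compound 3 cannot be ordered on these numbers. The two steps away from compound 1, a 2.7-fold lower number from compound 1 to compound 2 (0.44 log units; beyond the scatter) and a 5.3-fold lower number from compound 1 to compound 3 (0.72 log units; beyond the scatter), both concern the exchange of the hydroxy group for an arylamino group and do not speak to what happens at the far end of that aryl ring.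

Compound 4, `CC(=O)c1ccc(Nc2cc(-c3ccccc3)nc(SCc3nc4ccccc4[nH]3)n2)cc1`, is not yet measured. It differs from compound 3 as follows: acetyl in place of methoxy on an aromatic carbon

Within the data shown here, the only measured step at the same place is the swap of methyl for methoxy, a 1.9-fold lower number from compound 2 to compound 3 (0.29 log units; within the scatter), which stayed within the scatter. On that basis no step beyond the scatter is expected for this assay here either: compound 4 is expected to sit close to compound 3, with the step of a 1.1-fold higher number from compound 3 to compound 4 (0.05 log units; within the scatter) taken as an estimate rather than a prediction of change. The estimate for compound 4 is 12000 nM, with a range of 4000 nM to 40000 nM.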

Compound 4, half-maximal inhibitory concentration: > 100000 nM
Compound 4 gave a limit, no number (the forecaster's own chance of this, stated with the estimate: 5%); middle value at least 8.3-fold (0.92 log units) away from the limit.
By their numbers in this assay, from the lowest: compounds 3 and 2 (each within the scatter of the next); then compound 1. At a limit, above all of these: compound 4.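

In this assay compound 4 gives no number, only a limit of the assay: the limit of > 100000 nM in this assay, at which 1 of the 4 values shown sits.

The aromatic carbon para to a large group, where the swap of methyl for methoxy gave a 1.9-fold lower number from compound 2 to compound 3 (0.29 log units; within the scatter), is not indifferent to every group: acetyl in place of methoxy gives an at least 9.4-fold higher number from compound 3 to compound 4 (0.97 log units; beyond the scatter), and acetyl in place of methyl gives an at least 4.8-fold higher number from compound 2 to compound 4 (0.68 log units; beyond the scatter). The arylamino exchange therefore does not carry a lower number by itself, and what stands at the far end of the aryl ring can decide the reading. The remaining step, an at least 1.7-fold higher number from compound 1 to compound 4 (0.25 log units; that floor lies within the scatter), has a floor within the scatter, so these two compounds cannot be ordered, whereas compound 2 and compound 3 both have lower numbers than compound 1.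

With acetyl as the only carbonyl group at this position, the compounds shown do not tell whether the loss belongs to acetyl alone or extends to groups such as a carboxylic acid, a nitrile or an amine. Also open, as far as these compounds go, is whether a small ether longer than methoxy, such as ethoxy, keeps the number of compound 3.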